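Swapping methyl pattern on the aryl ether of compound 3

This account rests on a few compounds, and the source may have more. Where it says the series, first, only, none or still open, it means among the compounds named here.

Measured compounds:
compound 1 `Cc1ccccc1Cc1ccc(N2C[C@@H](C(F)(F)F)C[C@H]2CC(=O)O)cc1`, 710 nM
compound 2 `O=C(O)C[C@@H]1C[C@H](C(F)(F)F)CN1c1ccc(Oc2ccccc2C(F)(F)F)cc1`, 1300 nM
compound 3 `Cc1cccc(Oc2ccc(N3C[C@@H](C(F)(F)F)C[C@H]3CC(=O)O)cc2)c1C`, 500 nM

In a functional assay on cells for agonist activity at Free fatty acid receptor 1 (Mus musculus), read by FLIPR and calcium flux, with a stated time of 100 s (a higher number here means that more compound is needed for the effect, a lower number that less compound is needed), compound 3 gives the lowest number of the three measured compounds. Its gap to compound 1 is small, a 1.4-fold lower number from compound 1 to compound 3 (0.15 log units; within the scatter), so those two cannot be told apart. Its gap to compound 2 is larger, a 2.6-fold lower number from compound 2 to compound 3 (0.41 log units; beyond the scatter), a modest step.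

Compound 4 `Cc1cccc(C)c1Oc1ccc(N2C[C@@H](C(F)(F)F)C[C@H]2CC(=O)O)cc1` has not yet been measured. It differs from compound 3 in one place: 2,6-dimethylphenyl in place of 2,3-dimethylphenyl on an oxygen on an aromatic ring. Going by the values given here, of the measured steps, only the one from compound 2 to compound 3 touches the aryl group on that oxygen, and it exchanged a trifluoromethyl-bearing ring for a methyl-bearing one rather than moving a methyl around the same ring. The step from compound 1 to compound 3 changed the linker instead. Neither step shows how the arrangement of two methyls on that ring matters, so no step beyond the scatter in this assay is expected, and the estimated change is a 1.2-fold higher number from compound 3 to compound 4 (0.08 log units; within the scatter). Compound 4 is therefore expected to give about 600 nM, within a range of 250 nM to 1500 nM.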

Compound 4, half-maximal effective concentration: 270 nM
The estimate for compound 4 lay 2.2-fold (0.35 log units) above the measured number, within the range that was stated.
By their numbers in this assay, from the lowest: compounds 4, 3, 1 and 2 (each within the scatter of the next, the first and the last beyond it).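

In this assay, 2,6-dimethylphenyl in place of 2,3-dimethylphenyl on the oxygen gives a 1.9-fold lower number from compound 3 to compound 4 (0.27 log units; within the scatter), so these two arrangements of the same atoms cannot be told apart. Even so, the 2,6-dimethylphenoxy compound does stand apart from the 2-methylbenzyl compound, with a 2.6-fold lower number from compound 1 to compound 4 (0.42 log units; beyond the scatter), a separation that the 2,3-dimethylphenoxy compound did not reach, and it also stands apart from the 2-(trifluoromethyl)phenyl compound, with a 4.8-fold lower number from compound 2 to compound 4 (0.68 log units; beyond the scatter). Nothing available explains these numbers.

Going by these compounds, how 2,6-dichlorophenyl or 2,6-diethylphenyl on the same oxygen would read remains open. Also open, on these data alone, is whether a 2,6-dimethylbenzyl group on that aromatic carbon would match the 2,6-dimethylphenoxy group.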